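Fluoro-to-methyl swap read across a sulfonamide-to-amide gap

The source may report more compounds than this note shows. Statements on the series, on what has been measured and on what is new or still open speak of the compounds shown alone.

Measured in a functional assay on 3T3-L1 cells (Mus musculus) for inhibition, with a stated time of 20 min, tested at 20 uM; on this read-out lower numbers stand for less inhibition and higher numbers for more inhibition at the one concentration tested (going by the name of the read-out):
compound 1, `Cc1ccc(S(=O)(=O)N(Cc2cccc(F)c2F)Cc2cn(S(=O)(=O)c3ccc(C)cc3)c3ccccc23)cc1`: -13.9%
compound 2, `Cc1ccc(S(=O)(=O)N(Cc2cccc(F)c2F)Cc2cn(S(=O)(=O)c3ccc(F)cc3)c3ccccc23)cc1`: -35%
compound 3, `CC(=O)N(Cc1cccc(F)c1F)Cc1cn(S(=O)(=O)c2ccc(F)cc2)c2ccccc12`: 25.8%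

Compound 4, `CC(=O)N(Cc1cccc(F)c1F)Cc1cn(S(=O)(=O)c2ccc(C)cc2)c2ccccc12`, is not yet measured. It differs from compound 3 by methyl in place of fluoro on an aromatic carbon. The same change, (methyl in place of fluoro on an aromatic carbon), has been measured once already and gave a number 21.1 percentage points higher from compound 2 to compound 1 (beyond the scatter); among the compounds shown it occurs twice. The two cores differ by acetyl in place of (4-methylphenyl)sulfonyl on an amine nitrogen, a change that gave a number 60.8 percentage points higher from compound 2 to compound 3 (beyond the scatter), so the fluoro-to-methyl step is carried across the largest gap in the set. Compound 3 stands highest of the three values, and its gaps to the others lie beyond the scatter. Among the measured compounds shown here, for compound 4 a step of a number 19.2 percentage points higher from compound 3 to compound 4 (beyond the scatter) is expected, resting on the one measured instance of this change, a number 21.1 percentage points higher from compound 2 to compound 1 (beyond the scatter). Compound 4 is estimated at 45%, between 22% and 68%.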

Compound 4, a percentage reported as inhibition, at one concentration (the size of the read-out at that concentration, not a potency): 57.5%
The estimate for compound 4 lay 12.5 percentage points below the measured number; measured number inside the range.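

In this assay the change from 4-fluorophenyl to 4-methylphenyl gives a number 31.7 percentage points higher from compound 3 to compound 4 (beyond the scatter) and carries from the core of compound 2 to the core of compound 3 without a difference beyond the scatter: the same change on two cores in this assay, a number 21.1 percentage points higher (beyond the scatter) from compound 2 to compound 1 and a number 31.7 percentage points higher (beyond the scatter) from compound 3 to compound 4, 10.6 percentage points apart, within the scatter of two such steps.
Likewise, acetyl in place of (4-methylphenyl)sulfonyl on the amine nitrogen gives a number 71.4 percentage points higher from compound 1 to compound 4 (beyond the scatter) and matches the earlier step within the scatter: the same change on two cores in this assay, a number 60.8 percentage points higher (beyond the scatter) from compound 2 to compound 3 and a number 71.4 percentage points higher (beyond the scatter) from compound 1 to compound 4, 10.6 percentage points apart, within the scatter of two such steps.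
The two changes thus read as additive in this set, but that rests on four compounds tested at one concentration and shows neither why the steps agree nor that they hold on any other core.

Still open, going by these compounds, is whether the step holds with chloro or methoxy in the same place on the ring. Also open, on these data alone, is how a propanoyl group or a longer acyl chain would read in place of acetyl on the amine nitrogen.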